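The source may hold more compounds than are shown below. What is called first, only, known or untested is meant among the compounds shown, and "the series" means these compounds.

Of the compounds shown here, three have so far been measured in an ADME assay on microsomes from liver (Homo sapiens) for metabolic stability, read by LC-MS, with a stated time of 10 min, tested at 0.5 uM; on this read-out higher numbers stand for a more stable compound and lower numbers for a less stable compound. Compound 1 `c1ccc2c(c1)CN[C@@H](CN(CC[C@H]1CCCNC1)[C@H]1CCCc3cccnc31)C2` gives 93%, compound 3 `c1ccc2c(c1)CN[C@@H](CN(CCCCN1CCNCC1)[C@H]1CCCc3cccnc31)C2` gives 82%, and compound 2 `c1cnc2c(c1)CCC[C@@H]2N(CCCN1CCNCC1)Cc1nc2ccccc2s1` gives 50%, the lowest of the three. Among the measured compounds shown here, the only single-site step among them, a number 11 percentage points lower from compound 1 to compound 3 (beyond the scatter), concerns the chain end and leaves the aromatic group on the carbon bound to the amine nitrogen untouched. Compound 4 `c1cnc2c(c1)CCC[C@@H]2N(CCCN1CCNCC1)Cc1cc2ccccc2cn1` differs from compound 2 by isoquinolin-3-yl in place of 1,3-benzothiazol-2-yl on a saturated chain carbon bound to an amine nitrogen. For the measured compounds named here, no measured step covers this exchange, so the numbers give no direction for it. Compound 4 is therefore expected to show a step of no change at the digits printed from compound 2 to compound 4 (within the scatter), which should not go beyond the scatter. The estimate for compound 4 is 50%, with a range from 30% to 70%.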

Compound 4, percent of the compound remaining: 66%
Beside the measured number, compound 4's estimate is 16 percentage points below it; measured number inside the range.
By their numbers in this assay, from the lowest: compound 2; then compound 4; then compound 3; then compound 1.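

In this assay, the exchange of 1,3-benzothiazol-2-yl for isoquinolin-3-yl on a saturated chain carbon bound to an amine nitrogen gives a number 16 percentage points higher from compound 2 to compound 4 (beyond the scatter) and so shows that this place, untouched by the earlier step, bears on the read-out. The two groups differ at once in ring make-up, sulfur and hydrogen-bond acceptors, and this one step cannot separate these differences. Nothing available accounts for the rise. Going by these compounds, how a phenyl or a quinolin-2-yl group would read on this carbon stays open. So does whether the step would hold with another chain end.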